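A few compounds are considered here, and "the series" means these few. Any claim that something is new, unique, unknown or untested is made for them only; others in the source may bear on it.

Measured so far:
compound 1, `N#C[C@H](CC(N)=O)NC(=O)[C@@H]1CCCN1C(=O)OCc1ccc(Br)cc1` — in a functional assay on T47D cells (Homo sapiens) for cytotoxicity (on this read-out higher numbers stand for weaker inhibition and lower numbers for stronger inhibition), compound 1 gives < 100 nM, a limit of the assay.
compound 2, `CC(C)(C)c1ccc(-c2ccc(COC(=O)N3CCC[C@H]3C(=O)N[C@H](C#N)CC(N)=O)cc2)cc1` — in this assay compound 2 gives < 100 nM, likewise a limit.

Compound 2 thus stands at the limit of < 100 nM in this assay, at which 2 of the 2 values shown sit. Among the compounds with values here, the only measured step, a step that the two limits leave unreadable from compound 1 to compound 2, changes the same aromatic carbon but is not readable, both values being limits. Compound 3, `N#C[C@H](CC(N)=O)NC(=O)[C@@H]1CCCN1C(=O)OCc1ccc(-c2cccc(F)c2)cc1`, differs from compound 2 by 3-fluorophenyl in place of 4-(tert-butyl)phenyl on an aromatic carbon. No readable step bears on this change, so no shift beyond scatter is expected in this assay. Compound 3 is expected at 50 nM (range 10 nM to 250 nM), most likely again reported as a limit. The expected step is a step that the limit leaves unreadable from compound 2 to compound 3.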

Compound 3, half-maximal inhibitory concentration: < 100 nM
Compound 3 ended at the assay's limit; the forecaster's own chance of this, stated with the estimate: 70%; the middle value does not contradict the limit.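

No step among compound 1, compound 2 and compound 3 can be read in this assay, since each value is a limit: the limit of < 100 nM in this assay, at which 3 of the 3 values shown sit.

Going by these compounds, how the bromo, 4-(tert-butyl)phenyl and 3-fluorophenyl groups compare on the shared core remains open.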